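A few compounds are considered here, and "the series" means these few. Any claim that something is new, unique, unknown or untested is made for them only; others in the source may bear on it.

Measured so far:
compound 1, `COc1cc(Oc2cccc(Nc3ccccc3)c2)cc(OC)c1CNCc1ccccc1`, in a functional assay on HT-29 cells (Homo sapiens) for inhibition, read by MTT assay, with a stated time of 72 h (a lower number here means a stronger inhibitor, a higher number a weaker inhibitor), gives 3340 nM.
compound 2, `COc1ccc(CCCNCc2c(OC)cc(Oc3cccc(Nc4ccccc4)c3)cc2OC)cc1`, in this assay gives 3320 nM.
compound 3, `CCN1CCN(Cc2c(OC)cc(Oc3cccc(Nc4ccccc4)c3)cc2OC)CC1`, in this assay gives only a limit, > 20000 nM.

Compound 1 has the highest of the two numbers, yet a 1.0-fold lower number from compound 1 to compound 2 (0.00 log units; within the scatter) is within the scatter, so the two cannot be told apart. Compound 3 reached only the limit (the limit of > 20000 nM in this assay, at which 1 of the 3 values shown sits). The steps of an at least 5.9-fold higher number from compound 1 to compound 3 (0.77 log units; beyond the scatter) and an at least 6.0-fold higher number from compound 2 to compound 3 (0.77 log units; beyond the scatter) are beyond the scatter, but both replace the whole amine with a 4-ethylpiperazin-1-yl group rather than alter the benzyl ring.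

Compound 4, `COc1cc(Oc2cccc(Nc3ccccc3)c2)cc(OC)c1CNCc1ccc(O)cc1`, differs from compound 1 by hydroxy in place of hydrogen on an aromatic carbon. Among the compounds with values here, no measured step touches this aromatic carbon. The nearest guide is a 1.0-fold lower number from compound 1 to compound 2 (0.00 log units; within the scatter), where a far larger change on the saturated chain carbon bound to the amine nitrogen stayed within the scatter. The expected step is therefore small, a 1.1-fold lower number from compound 1 to compound 4 (0.05 log units; within the scatter), with no direction beyond the scatter. Compound 4 is estimated at 3000 nM, with a range from 1200 nM to 8000 nM.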

Compound 4, half-maximal inhibitory concentration: 2180 nM
Compound 4: the middle estimate sits 1.4-fold (0.14 log units) above what was measured; measured number inside the range.
By their numbers in this assay, from the lowest: compounds 4, 2 and 1 (each within the scatter of the next). At a limit, above all of these: compound 3.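

Hydroxy in place of hydrogen, para to a large group, is the only change shown on this aromatic ring, and the ring tolerates it in this assay: a 1.5-fold lower number from compound 1 to compound 4 (0.19 log units; within the scatter) stays within the scatter, and so does a 1.5-fold lower number from compound 2 to compound 4 (0.18 log units; within the scatter), so the three amines with an aromatic ring on their chain cannot be told apart. The step to the piperazine compound also holds with the new group in place, as an at least 9.1-fold lower number from compound 3 to compound 4 (0.96 log units; beyond the scatter) lies beyond the scatter. Compound 3 gives only a limit: the limit of > 20000 nM in this assay, at which 1 of the 4 values shown sits.

From the compounds shown here alone, whether an amine or a carboxylic acid in place of this hydroxy would move the number beyond the scatter stays open. A single group at a single place also cannot show how far this tolerance extends around the ring.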